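Decyl tail in place of the dihydroxyphenyl amide

The source may hold more compounds than are shown below. What is called first, only, known or untested is meant among the compounds shown, and "the series" means these compounds.

Measured so far:
compound 1 `Cn1c(Cc2nn(C)c(=O)c3ccccc23)nnc1SCCCCCCCC(=O)Nc1ccc(O)cc1O` gives 17000 nM
compound 2 `CN(C(=O)CSc1nnc(Cc2nn(C)c(=O)c3ccccc23)n1C)c1ccc(Cl)cc1Cl` gives > 30000 nM, which is a limit of the assay and not a number
compound 3 `CC(C)Oc1ccc(NC(=O)CCCCCCCSc2nnc(Cc3nn(C)c(=O)c4ccccc34)n2C)cc1` gives 1100 nM

Within the data shown here, in an assay on isolated protein (Mus musculus) for inhibition of IL15-IL15 receptor (Homo sapiens), read by resazurin assay, with stated times of 30 min and 2.5 days (a lower number here means a stronger inhibitor, a higher number a weaker inhibitor), compound 1 holds the highest of the two numbers; the only single-place step measured is a 15-fold lower number from compound 1 to compound 3 (1.19 log units; beyond the scatter). Compound 2 sits at the limit of > 30000 nM in this assay, at which 1 of the 3 values shown sits. Compound 4 `CCCCCCCCCCSc1nnc(Cc2nn(C)c(=O)c3ccccc23)n1C` differs from compound 1 by propyl in place of (2,4-dihydroxyphenyl)carbamoyl on a saturated chain carbon, seven bonds along the chain from a sulfur. Among the measured compounds shown here, no measured step covers loss of the whole aryl amide; the step from compound 1 to compound 3 only exchanges the aryl group. The expectation is therefore a step of a 1.1-fold lower number from compound 1 to compound 4 (0.05 log units; within the scatter), uncertain in direction and not clearly beyond the scatter. Compound 4 is estimated at 15000 nM, in the range 3000 nM to 60000 nM.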

Compound 4, half-maximal inhibitory concentration: 7600 nM
Compound 4: the middle estimate sits 2.0-fold (0.30 log units) above what was measured; the range from low to high includes it.
By their numbers in this assay, from the lowest: compound 3; then compound 4; then compound 1. At a limit, above all of these: compound 2.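

In this assay, propyl in place of (2,4-dihydroxyphenyl)carbamoyl gives a 2.2-fold lower number from compound 1 to compound 4 (0.35 log units; beyond the scatter), so at this chain position the series keeps a measurable number without any aryl amide. Compound 3, which keeps the amide with a 4-isopropoxyphenyl group, still holds the lowest number, 1100 nM. Nothing measured here accounts for the step.

Open, on these data alone, is whether a carboxylic acid or an amine at the chain end would keep the number of compound 4. Also open, as far as these compounds go, is how a longer chain than the decyl tail would read.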